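The compounds below may be only part of what the source reports. "The series", "measured", "known", "first", "only" and "open" are said of these compounds alone.

Compound 1 `CC(Oc1ncnc2ccc(-c3cnn(C4CCNCC4)c3)cc12)c1c(Cl)ccc(F)c1Cl`: 2500 nM.
Compound 2 `CC(Nc1ncnc2ncc(-c3cnn(C4CCNCC4)c3)cc12)c1c(Cl)ccc(F)c1Cl`: 17700 nM.
Compound 3 `CC(Nc1ncnc2ncc(-c3cnn(C)c3)cc12)c1c(Cl)ccc(F)c1Cl`: > 100000 nM, a limit rather than a number.

In a functional assay on SK-BR-3 cells (Homo sapiens) for antiproliferative activity, read by MTT assay, with a stated time of 72 h (a lower number here means a stronger inhibitor, a higher number a weaker inhibitor), compound 1 gives 2500 nM, the lower of the two measured numbers. Compound 2 gives 17700 nM. Compound 3 stops at the limit of > 100000 nM, which is the limit (the limit of > 100000 nM in this assay, at which 1 of the 3 values shown sits). Compound 1 and compound 2 differ in more than one place, and the difference between their cores is not broken down here. Compound 3 arises from compound 2 by a single change, (methyl in place of piperidin-4-yl on an aromatic nitrogen), and this gave an at least 5.6-fold higher number from compound 2 to compound 3 (0.75 log units; beyond the scatter). Compound 4 `CC(Oc1ncnc2ccc(-c3cnn(C)c3)cc12)c1c(Cl)ccc(F)c1Cl`, not yet measured, arises from compound 1 by the same change, (methyl in place of piperidin-4-yl on an aromatic nitrogen). Because the measured step of an at least 5.6-fold higher number from compound 2 to compound 3 (0.75 log units; beyond the scatter) was at least modest, a weakening of similar size is expected here, so compound 4 is expected at a 12-fold higher number from compound 1 to compound 4 (1.08 log units; beyond the scatter). Compound 4 is therefore estimated at 30000 nM, most likely between 10000 nM and 100000 nM.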

Compound 4, half-maximal inhibitory concentration: 27200 nM
Compound 4: middle estimate off by 1.1-fold (0.04 log units), on the high side, and the stated range covers the measured number.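

In this assay, placing methyl in place of piperidin-4-yl on the aromatic nitrogen also weakens the compound on the core of compound 1, with an 11-fold higher number from compound 1 to compound 4 (1.04 log units; beyond the scatter). The change therefore points the same way on both cores shown, which are only two cores in one assay: the same change on two cores in this assay, an at least 5.6-fold higher number (0.75 log units; beyond the scatter) from compound 2 to compound 3 and an 11-fold higher number (1.04 log units; beyond the scatter) from compound 1 to compound 4; the limit leaves it open whether they differ. Whether the step has the same size on both cores stays unsettled, as the value of compound 3 is a limit and not a number: the limit of > 100000 nM in this assay, at which 1 of the 4 values shown sits.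

The compounds shown leave open whether the ring of piperidin-4-yl or its nitrogen matters more. A cyclohexyl group, which has the ring without the nitrogen, or a short chain ending in an amine, which has a nitrogen without the ring, could help separate the two.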